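A few compounds are considered here, and "the series" means these few. Any claim that something is new, unique, unknown or untested is made for them only; others in the source may bear on it.

In a functional assay on HCT-116 cells (Homo sapiens) for antiproliferative activity, read by MTT assay, with a stated time of 72 h (on this read-out higher numbers stand for weaker inhibition and lower numbers for stronger inhibition), compound 1 `CC(C)(C)OC(=O)NCc1ccc(NC(=O)CCc2cccc3c2B(O)OC3)cc1` gives 2300 nM. Compound 2 `CCOC(=O)c1ccc(NC(=O)CCc2cccc3c2B(O)OC3)cc1` gives > 100000 nM, which is a limit of the assay and not a number. Compound 3 `O=C(CCc1cccc2c1B(O)OC2)Nc1ccc(-c2ccccc2)cc1` has not yet been measured and keeps the shared core. Its structure differs from that of compound 2 in one place: phenyl in place of ethoxycarbonyl on an aromatic carbon. Going by the values given here, one measured step bears on this change: an at least 43-fold higher number from compound 1 to compound 2 (1.63 log units; beyond the scatter), a large step beyond the scatter, and it shows that a swap at this place can shift the read-out strongly. Here ethoxycarbonyl leaves again, so some return toward stronger inhibition is expected, although the starting point is only a limit and the size stays uncertain. The expected change is an at least 6.6-fold lower number from compound 2 to compound 3 (0.82 log units; beyond the scatter). For compound 3 the estimated value is 15000 nM, with an expected range from 2500 nM to 100000 nM.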

Compound 3, half-maximal inhibitory concentration: 13000 nM
Compound 3: the middle estimate sits 1.2-fold (0.06 log units) above what was measured, and the stated range covers the measured number.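

In this assay, the swap of ethoxycarbonyl for phenyl on this aromatic carbon gives an at least 7.6-fold lower number from compound 2 to compound 3 (0.88 log units; beyond the scatter), so a measurable value at this place does not need the ((tert-butoxycarbonyl)amino)methyl of compound 1, and phenyl, with 0 hydrogen-bond donors and 0 hydrogen-bond acceptors, is enough to reach one. That group is still not matched, for the swap to phenyl gives a 5.7-fold higher number from compound 1 to compound 3 (0.75 log units; beyond the scatter). The value of compound 2 is a limit and not a number, so the first step gives only a bound on its size: the limit of > 100000 nM in this assay, at which 1 of the 3 values shown sits.

From the compounds shown here alone, it remains open how a free aminomethyl or a carboxylic acid would read at this place. The three compounds also do not tell which part of ((tert-butoxycarbonyl)amino)methyl carries its difference from phenyl.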